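Swapping the amide acyl group for a thiophenesulfonyl

This account rests on a few compounds, and the source may have more. Where it says the series, first, only, none or still open, it means among the compounds named here.

For the measured compounds named here, compound 2 `CCCCCCCCCCCCCCNC(=O)[C@@H](NC(=O)c1cc2ccccc2[nH]1)[C@@H](C)O` gives 12300 nM in a functional assay on A-431 cells (Homo sapiens) for cytotoxicity, read by MTT assay, with a stated time of 48 h (a higher number here means a weaker inhibitor, a lower number a stronger inhibitor), the lower of the two numbers known; its nearest neighbour, compound 1 `CCCCCCCCCCCCCCNC(=O)[C@@H](NC(=O)c1ccccc1)[C@@H](C)O`, gives 118000 nM, and the step of a 9.6-fold lower number from compound 1 to compound 2 (0.98 log units; beyond the scatter) is the only one measured. Compound 3 `CCCCCCCCCCCCCCNC(=O)[C@@H](NS(=O)(=O)c1cccs1)[C@@H](C)O` differs from compound 2 by (thiophen-2-yl)sulfonyl in place of (1H-indol-2-yl)carbonyl on an amine nitrogen. Going by the values given here, the measured step bears on it only loosely, as it altered the aromatic group while keeping the carbonyl; no step tests a sulfonyl in that place. The author expects a weaker inhibitor, the step being a 4.1-fold higher number from compound 2 to compound 3 (0.61 log units; beyond the scatter). The estimate for compound 3 is 50000 nM in this assay, within 15000 nM to 200000 nM.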

Compound 3, half-maximal inhibitory concentration: 22000 nM
Estimate against measurement, compound 3: 2.3-fold (0.36 log units) above; the range from low to high includes it.
By their numbers in this assay, from the lowest: compounds 2 and 3 (each within the scatter of the next); then compound 1.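

In this assay, a sulfonyl on the amine nitrogen keeps the number within the scatter of the (1H-indol-2-yl)carbonyl compound (a 1.8-fold higher number from compound 2 to compound 3 (0.25 log units; within the scatter)). Against the benzoyl compound, the same group is beyond the scatter (a 5.4-fold lower number from compound 1 to compound 3 (0.73 log units; beyond the scatter)), so a gain over benzoyl does not depend on a carbonyl or on the six-membered aromatic ring of the indole. Nothing measured here accounts for this result. The linker and the aromatic ring changed together, and the compounds shown do not separate their shares. A benzenesulfonyl or a thiophene-2-carbonyl group on that nitrogen would bear on this.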